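Chloro for Methoxy: Three Values at the Limit

The compounds below may be only part of what the source reports. "The series", "measured", "known", "first", "only" and "open" are said of these compounds alone.

Compound 1, `COc1ccc(CN2CCCCC2CCOc2ccc(-c3nc4cc(C(N)=O)ccc4[nH]3)cc2)cc1`, in a physicochemical assay for solubility, with a stated time of 3 days, at pH 2 (on this read-out lower numbers stand for lower solubility and higher numbers for higher solubility), gives a limit, > 400000 nM.
Compound 2, `NC(=O)c1ccc2[nH]c(-c3ccc(OCCC4CCCCN4Cc4ccc(Cl)cc4)cc3)nc2c1`, gives a limit, > 400000 nM.
Compound 3, `COc1ccc(CN2CCC(CCOc3ccc(-c4nc5cc(C(N)=O)ccc5[nH]4)cc3)CC2)cc1`, gives a limit, > 400000 nM.

All three measured values are limits rather than numbers, each reported as the limit of > 400000 nM in this assay, at which 3 of the 3 values shown sit. Compound 2 differs from compound 1 by chloro in place of methoxy on an aromatic carbon. The resulting step, a step that the two limits leave unreadable from compound 1 to compound 2, cannot be sized because of the limit of > 400000 nM in this assay, at which 3 of the 3 values shown sit. Compound 3 has the same atoms as compound 1 joined differently; the difference between the two cores is not broken down here.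

Compound 4, `NC(=O)c1ccc2[nH]c(-c3ccc(OCCC4CCN(Cc5ccc(Cl)cc5)CC4)cc3)nc2c1`, has not yet been measured in this assay. It differs from compound 3 by chloro in place of methoxy on an aromatic carbon, the same change as that from compound 1 to compound 2, at the same kind of place. The step from compound 3 to compound 4 is expected to be a number no higher from compound 3 to compound 4 (the limit leaves the size open), resting on the fact that the earlier step, a step that the two limits leave unreadable from compound 1 to compound 2, left both compounds at the limit of > 400000 nM in this assay, at which 3 of the 3 values shown sit. Compound 4 is therefore estimated at about 400000 nM, most likely again reported only as a limit, with a plausible range from 150000 nM to 1200000 nM.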

Compound 4, solubility: 179000 nM
The estimate for compound 4 lay 2.2-fold (0.35 log units) above the measured number; the measured number falls inside the stated range.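

In this assay, chloro in place of methoxy on an aromatic carbon comes with an at least 2.2-fold lower number from compound 3 to compound 4 (0.34 log units; beyond the scatter), a change that can be read on this one core and lies beyond the usual scatter. Within the data shown here, the same replacement on the core of compound 1 gives a step that cannot be read, because both of its compounds are limits, not numbers: the limit of > 400000 nM in this assay, at which 3 of the 4 values shown sit. The data therefore do not show that the change carries from one core to the other with the same direction or size, and since compound 3 is itself a limit, the full size of the one readable step also stays unknown.

The compounds shown carry only methoxy or chloro at this place, so it remains open what another group there, such as a nitrile or an amine, would give. Also open, as far as these compounds go, is how the two cores compare when both carry chloro, since compound 2 is only a limit.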